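Second chloro on the benzyl ring: compound 3

A few compounds are considered here, and "the series" means these few. Any claim that something is new, unique, unknown or untested is made for them only; others in the source may bear on it.

Compound 2 `COc1ccc2nccc(C3CN(C4CCN(Cc5cccc(Cl)c5)CC4)C(=O)O3)c2c1` stands at the higher of the two measured numbers: in an in vitro functional assay on RBL cells for antagonist activity at C-C chemokine receptor type 8 (Homo sapiens), read by FLIPR and calcium flux (a lower number here means a stronger inhibitor, a higher number a weaker inhibitor), compound 2 gives 6310 nM. Compound 1 `COc1ccc2nccc(C3CN(C4CCN(Cc5cc6ccccc6[nH]5)CC4)C(=O)O3)c2c1` gives 25.1 nM in this assay. For the measured compounds named here, the only measured step, a 250-fold higher number from compound 1 to compound 2 (2.40 log units; beyond the scatter), exchanges the whole aryl group on the saturated chain carbon bound to the ring amine nitrogen and shows that this region moves the number strongly.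

Compound 3 `COc1ccc2nccc(C3CN(C4CCN(Cc5ccc(Cl)c(Cl)c5)CC4)C(=O)O3)c2c1` differs from compound 2 by chloro in place of hydrogen on an aromatic carbon. Going by the values given here, no measured step adds or removes a single substituent on that six-membered ring, so the aryl swap is the only comparison at hand, and it bears on the change only indirectly: it marks the region as sensitive but gives no direction for a second chloro placed ortho to the first and para to the large group. The expected step is therefore a 2.1-fold lower number from compound 2 to compound 3 (0.32 log units; beyond the scatter), small and uncertain, leaning toward a somewhat lower number. The estimate for compound 3 in this assay is 3000 nM, with a range from 800 nM to 12000 nM.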

Compound 3, half-maximal inhibitory concentration: 126 nM
The estimate for compound 3 lay 24-fold (1.38 log units) above the measured number; measured number outside the range, below it.
By their numbers in this assay, from the lowest: compound 1; then compound 3; then compound 2.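

In this assay, the aromatic carbon ortho to a chloro group and para to a large group proves to be a strong lever in its own right: chloro in place of hydrogen there gives a 50-fold lower number from compound 2 to compound 3 (1.70 log units; beyond the scatter) and so ties much of the sensitivity of this region to a single added atom, where the earlier comparison had exchanged the whole aryl group. The 3,4-dichlorophenyl group also recovers most of the ground lost with the 3-chlorophenyl group, leaving only a 5.0-fold higher number from compound 1 to compound 3 (0.70 log units; beyond the scatter) against the earlier 250-fold higher number from compound 1 to compound 2 (2.40 log units; beyond the scatter) and showing that an aromatic ring of carbon only can come within a modest, though still beyond-scatter, distance of the 1H-indol-2-yl compound. For the compounds shown here, nothing available explains why this one chloro moves the number so far.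

Still open, as far as these compounds go, is whether the entering chloro would give a step of this size without the chloro it sits ortho to, or whether the step depends on the two together. From the compounds shown here alone, it is also open whether bromo, methyl, trifluoromethyl or nitrile on the same aromatic carbon would match chloro.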